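A few compounds are considered here, and "the series" means these few. Any claim that something is new, unique, unknown or untested is made for them only; others in the source may bear on it.

Measured so far in an in vitro assay on cells for inhibition of Amine oxidase [flavin-containing] B (Homo sapiens), read by coupled enzyme assay, with a stated time of 20 min; on this read-out lower numbers stand for stronger inhibition and higher numbers for weaker inhibition: compound 1 `Cn1c(=O)c2c(nc(CCSc3ccc(Br)cc3)n2C)n(C)c1=O` gives 124000 nM; compound 2 `COc1cccc(OCc2nc3c(c(=O)n(C)c(=O)n3C)n2C)c1` gives 1960 nM; compound 3 `Cn1c(=O)c2c(nc(CCSc3ccc(Cl)cc3)n2C)n(C)c1=O` gives 7790 nM.

Compound 2 stands lowest of the three, with compound 3 nearest and compound 1 furthest, both gaps beyond the scatter. Compound 4 `Cn1c(=O)c2c(nc(COc3cccc(Cl)c3)n2C)n(C)c1=O` differs from compound 2 by chloro in place of methoxy on an aromatic carbon. Among the compounds with values here, the only measured step, a 16-fold lower number from compound 1 to compound 3 (1.20 log units; beyond the scatter), concerns the exchange of one halogen for another and does not bear directly on the exchange of methoxy for chloro; no measured pair shows that change. Therefore no step beyond the scatter is expected in this assay in either direction, and the estimated change is a 1.0-fold higher number from compound 2 to compound 4 (0.01 log units; within the scatter). Compound 4 is expected to give about 2000 nM, within 600 nM to 7000 nM.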

Compound 4, half-maximal inhibitory concentration: 334 nM
The estimate for compound 4 lay 6.0-fold (0.78 log units) above the measured number; measured number outside the range, below it.
By their numbers in this assay, from the lowest: compound 4; then compound 2; then compound 3; then compound 1.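

In this assay, within the data shown here, chloro in place of methoxy on an aromatic carbon gives a 5.9-fold lower number from compound 2 to compound 4 (0.77 log units; beyond the scatter), so this place on the six-membered ring does respond to the exchange, something the earlier compounds could not show. The step swaps a group of two heavy atoms and one hydrogen-bond acceptor for a single heavy atom with no acceptor. Nothing available here accounts for the size of this step. Going by these compounds, whether fluoro, bromo or an amine at the same carbon would move the number further remains open. Among these compounds, since this single pair is the only record of the exchange, it also remains open whether the step would recur in another compound.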